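The source may report more compounds than this note shows. Statements on the series, on what has been measured and on what is new or still open speak of the compounds shown alone.

Of the compounds shown here, three sharing a pyroglutamyl-peptide core have been measured in a functional assay on the whole organism for inhibition, with Rattus norvegicus as the target, at a dose of 80 mg/kg by the intravenous route; a higher number here means more inhibition at the dose given (going by the name of the read-out), a lower number less inhibition. Compound 1 `NC(=O)[C@H]1CCCN1C(=O)CNC(=O)[C@H]1CCC(=O)N1` gives 10%. Compound 2 `CCCCCCCC[C@H](NC(=O)[C@@H]1CCC(=O)N1)C(=O)N1CCC[C@H]1C(N)=O` gives 0%. Compound 3 `CCCCCCCCCCNC(=O)[C@H]1CCCN1C(=O)[C@@H](CC(C)C)NC(=O)[C@H]1CCC(=O)N1` gives 10%. On these numbers compound 3 is level with compound 1 at the digits shown, and together they carry the highest of the three readings, while the gap down to compound 2 lies within the usual scatter of this measurement, so none of the three can be set apart from the others.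

Compound 4 `CC(C)C[C@@H](NC(=O)[C@H]1CCC(=O)N1)C(=O)N1CCC[C@@H]1C(=O)NCCN(C)C` has not yet been measured. It differs from compound 3 in one place: dimethylamino in place of octyl on a saturated chain carbon, two bonds along the chain from an amide-type nitrogen. The octyl chain at the end of the molecule is thus cut back and replaced by a dimethylamino group, giving a shorter, nitrogen-capped tail in place of a long hydrocarbon one.

Within the data shown here, no pair of measured compounds differs by a single change, so there is no directly comparable step to lean on. Because compound 3 gives 10% and the whole set sits at low inhibition, the expected step is no change at the digits printed from compound 3 to compound 4 (within the scatter), which is to say no change beyond the scatter in either direction. Compound 4 is therefore expected to give about 10%, within a range from 0% to 25%.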

Compound 4, a percentage reported as inhibition, in the whole organism at one dose (the size of the read-out at that dose, not a potency): 10%
Compound 4: middle estimate and measured number agree at the digits printed, within the range that was stated.
By their numbers in this assay, from the lowest: compounds 2, 1, 3 and 4 (each within the scatter of the next).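

In this assay, putting dimethylamino in place of octyl on a saturated chain carbon, two bonds along the chain from an amide-type nitrogen, gives no change at the digits printed from compound 3 to compound 4 (within the scatter). Among these compounds, this is the first comparison in the set in which only one place differs, and it shows that at this position a long hydrocarbon chain can give way to a shorter tail capped by a nitrogen without the reading moving beyond the scatter. No measurement shown here explains why the two readings match.

Going by these compounds, it remains open whether a carboxylic acid or a hydroxyl group at this same position would shift the reading beyond the scatter, or whether a longer chain than octyl would do so. Among the compounds shown here, compound 1 and compound 2 each differ from this pair in more than one place, so no step to them can be read, and with every reading in the set low, it also remains unclear how this change would behave on a compound giving much stronger inhibition.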